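The compounds below may be only part of what the source reports. "The series", "measured", "known", "first", "only" and "open" are said of these compounds alone.

Series notes: the shared core carries a bis(trifluoromethyl)benzyl amide; compound 1 `CC(C)(C)OC(=O)N1CC[C@H](c2ccccc2)[C@@H](C(=O)NCc2cc(C(F)(F)F)cc(C(F)(F)F)c2)C1`, compound 2 `CN(Cc1cc(C(F)(F)F)cc(C(F)(F)F)c1)C(=O)[C@H]1CN(C(=O)C2CCCCC2)C[C@@H]1c1ccccc1` and compound 3 `CC(=O)N1CCC(C(=O)N2C[C@H](C(=O)N(C)Cc3cc(C(F)(F)F)cc(C(F)(F)F)c3)[C@@H](c3ccc(F)cc3C)C2)CC1` have been measured in an assay on CHO cells for displacement of a labelled ligand from Substance-P receptor (Homo sapiens); a higher number here means a weaker inhibitor, a lower number a stronger inhibitor. Compound 1 gives 450 nM in this assay. Compound 2 gives 0.68 nM, and compound 3 gives 0.05 nM. Of the three numbers, compound 2 stands second highest: compound 3 is its nearest neighbour, with a lower number beyond the scatter, and compound 1 is furthest, with a higher number far beyond the scatter. Among the compounds with values here, no single-point step between two measured compounds is available, so none is described here.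

Compound 4 `CN(Cc1cc(C(F)(F)F)cc(C(F)(F)F)c1)C(=O)[C@H]1CN(C(=O)c2cnccn2)C[C@@H]1c1ccccc1` has not yet been measured in this assay. Against compound 2 the change is pyrazin-2-yl in place of cyclohexyl on a carbonyl carbon. The group at that carbonyl carbon has no measured comparison within the set; compound 2 and compound 3 differ in several places at once, so their gap cannot be attributed to this position.

For compound 4 a step from compound 2 of a 1.8-fold higher number from compound 2 to compound 4 (0.25 log units; within the scatter) is expected, which lies within the scatter or only slightly above it, towards a higher number. The estimate for compound 4 in this assay is 1.2 nM, with a range of 0.3 nM to 5 nM.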

Compound 4, half-maximal inhibitory concentration: 0.74 nM
Beside the measured number, compound 4's estimate is 1.6-fold (0.21 log units) above it; measured number inside the range.
By their numbers in this assay, from the lowest: compound 3; then compounds 2 and 4 (each within the scatter of the next); then compound 1.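

In this assay, within the data shown here, pyrazin-2-yl in place of cyclohexyl on the carbonyl carbon gives a 1.1-fold higher number from compound 2 to compound 4 (0.04 log units; within the scatter), the first comparison that isolates a single place. At this position, on a carbonyl carbon bound to an amide-type nitrogen in a ring, a six-membered aromatic ring with 2 hetero atoms and 2 hydrogen-bond acceptors therefore reads the same, within the scatter, as a six-membered carbon-only ring with 0 hydrogen-bond acceptors, so neither aromaticity nor the hetero atoms separate these two groups in this assay. No measurement is available that explains why the two groups read alike.

On these data alone, it remains open whether this flat reading extends beyond these two rings of 6 heavy atoms to other groups on the same carbonyl carbon, such as a piperidin-4-yl ring with a free amine, a carboxylic acid or a longer alkyl chain. The steps at the other places where compound 1, compound 2 and compound 3 differ cannot be read, as those compounds differ in several places at once.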